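The source may report more compounds than this note shows. Statements on the series, on what has been measured and on what is new or still open speak of the compounds shown alone.

For the measured compounds named here, compound 1, with the structure `COc1cc(-c2ccnc3cc(-c4ccc(Cl)cc4)nn23)cc(OC)c1OC`, is the only member of this small set for which a number rather than a limit is known. In a functional assay on A549 cells (Homo sapiens) for inhibition, read by CCK-8 assay, with a stated time of 48 h (a higher number here means a weaker inhibitor, a lower number a stronger inhibitor), compound 1 gives 3070 nM. Compound 2, the structure `COc1cc(-c2ccnc3c(-c4ccc(C)cc4)cnn23)cc(OC)c1OC`, reaches only the limit of this assay, recorded as > 10000 nM. Compound 3, the structure `COc1ccc(-c2cc3nccc(-c4cc(OC)c(OC)c(OC)c4)n3n2)cc1[N+](=O)[O-]`, likewise stops at the limit of this assay, recorded as > 10000 nM. So compound 1 stands alone with a measured value, and two of the three values shown sit at the limit, as the summary the limit of > 10000 nM in this assay, at which 2 of the 3 values shown sit, states.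

Compound 4, the structure `COc1cc(-c2ccnc3cc(-c4ccc(C(C)=O)cc4)nn23)cc(OC)c1OC`, has not yet been measured in this assay. It differs from compound 1 in one place only: acetyl in place of chloro on an aromatic carbon. Going by the values given here, no pair of measured compounds in this set differs by a single change, so there is no measured step to lean on for the size of this one. With both neighbours of compound 1 sitting at the limit, the step is expected to be modest, in either direction, and likely no larger than the usual scatter; the expected step from compound 1 to compound 4 is a 1.3-fold higher number from compound 1 to compound 4 (0.11 log units; within the scatter). Compound 4 is therefore estimated to give 4000 nM in this assay, with a range from 1500 nM to 10000 nM.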

Compound 4, half-maximal inhibitory concentration: 4100 nM
Beside the measured number, compound 4's estimate is 1.0-fold (0.01 log units) below it, and the stated range covers the measured number.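

The earlier compounds shown here offered no measured step on the aromatic carbon para to a large group, so nothing showed how much a change there would matter. In this assay, replacing chloro with acetyl on the 4-substituted phenyl gives a 1.3-fold higher number from compound 1 to compound 4 (0.13 log units; within the scatter), so two quite different groups read the same within the scatter: acetyl brings more heavy atoms, a double bond outside the aromatic rings and a hydrogen-bond acceptor, while chloro has none of these. This position can therefore carry either group with no readable change in the number, although this single pair says nothing about the reason, and nothing given here bears on the cause.

The compounds shown leave open whether this tolerance extends to quite different groups at the same place, such as an amine, a carboxylic acid or a longer chain, and whether any of them would give a number clearly lower than those of compound 1 and compound 4. Much of the set also offers no exact number for comparison, only a limit: the limit of > 10000 nM in this assay, at which 2 of the 4 values shown sit.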